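A few compounds are considered here, and "the series" means these few. Any claim that something is new, unique, unknown or untested is made for them only; others in the source may bear on it.

Compound 1 `COc1ccc(-c2cc(/C=C/C(=O)c3ccc(OC)c(OC)c3)nc3cc(-c4ccccc4)nn23)cc1` gives 7400 nM in a functional assay on A549 cells (Homo sapiens) for antiproliferative activity, read by MTT assay, with a stated time of 24 h; a higher number here means a weaker inhibitor, a lower number a stronger inhibitor.
Compound 2 `COc1ccc(C(=O)/C=C/c2cc(-c3ccc(OC)c(OC)c3)n3nc(-c4ccccc4)cc3n2)cc1` gives 11900 nM in this assay.
Compound 3 `COc1ccc(-c2cc(C(=O)/C=C/c3ccc(C)cc3)nc3cc(-c4ccccc4)nn23)cc1OC` gives 22200 nM in this assay.

Among these three numbers compound 2 stands second highest. Its nearest neighbour is compound 1, whose number is lower but within the scatter of compound 2; its furthest is compound 3, reached by a 1.9-fold higher number from compound 2 to compound 3 (0.27 log units; within the scatter), a step that also stays within the scatter. So the three measured compounds are not distinguished from one another in this assay.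

Compound 4 `COc1ccc(C(=O)/C=C/c2cc(-c3ccc(OC)cc3)n3nc(-c4ccccc4)cc3n2)cc1` is the compound still to be measured. It differs from compound 2 by hydrogen in place of methoxy on an aromatic carbon.

Going by the values given here, only one measured step exists, a 1.9-fold higher number from compound 2 to compound 3 (0.27 log units; within the scatter), and it alters a different part of the molecule; no measured pair tests the loss of a methoxy from the 3,4-dimethoxyphenyl group. Among the compounds with values here, the one step that is known was within the scatter, and the three numbers together spread over less than the scatter. On that basis compound 4 is expected to stay close to compound 2, with a 1.0-fold higher number from compound 2 to compound 4 (0.00 log units; within the scatter) as the expected step, no larger than the scatter and of no settled direction. The estimate for compound 4 is therefore 12000 nM, with a range from 5000 nM to 30000 nM.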

Compound 4, half-maximal inhibitory concentration: 2900 nM
The estimate for compound 4 lay 4.1-fold (0.62 log units) above the measured number; the measured number lies below the stated range.
By their numbers in this assay, from the lowest: compound 4; then compounds 1, 2 and 3 (each within the scatter of the next, the first and the last beyond it).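

Going by these compounds alone, the exchange of 3,4-dimethoxyphenyl for 4-methoxyphenyl gives a 4.1-fold lower number from compound 2 to compound 4 (0.61 log units; beyond the scatter) in this assay, the first step in this set to pass beyond the scatter, though it remains modest. Compound 1 carries its 3,4-dimethoxyphenyl group at a different place in the molecule, and the same exchange there gives a 2.6-fold lower number from compound 1 to compound 4 (0.41 log units; beyond the scatter), so removing this one methoxy goes with a lower number at both places, and no pair shown goes against this. Nothing available explains why the number falls at either place.

On these data alone, it remains open whether the gain depends on the methoxy being absent or whether another small group on the same aromatic carbon, such as a fluorine atom, a hydroxy group or an ethoxy group, would give a similar number. It is also unknown whether removing the remaining methoxy from the 4-methoxyphenyl groups of compound 4, or replacing it with a chlorine atom or a dimethylamino group, would lower the number further or raise it.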